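Methoxy for methyl on the core of compound 1

The source may hold more compounds than are shown below. What is called first, only, known or untested is meant among the compounds shown, and "the series" means these compounds.

Compound 1 `COc1ccc(S(=O)(=O)c2cnc3ccc(C)cc3c2N2CCC(C)CC2)cc1Cl` was tested in an assay on isolated protein for displacement of a labelled ligand from metabotropic glutamate receptor 5 (Homo sapiens), with a stated time of 60 min, tested at 1 uM (on this read-out lower numbers stand for less inhibition and higher numbers for more inhibition at the one concentration tested (going by the name of the read-out)), where compound 1 gives 93%. It stands level with compound 3 `Cc1ccc2ncc(S(=O)(=O)c3ccc(F)c(Cl)c3)c(N3CCC(C)CC3)c2c1`, which gives 93%, and the two together sit at the top of the three numbers: no change at the digits printed from compound 1 to compound 3 (within the scatter). Compound 2 `Cc1ccc2ncc(S(=O)(=O)c3cccc(C#N)c3)c(N3CCC(C)CC3)c2c1` gives 52%, with a number 41 percentage points lower from compound 1 to compound 2 (beyond the scatter) and a number 41 percentage points higher from compound 2 to compound 3 (beyond the scatter). Compound 4 `COc1ccc2ncc(S(=O)(=O)c3ccc(OC)c(Cl)c3)c(N3CCC(C)CC3)c2c1` differs from compound 1 in one place: methoxy in place of methyl on an aromatic carbon. Among the compounds with values here, none of the measured steps touches this part of the shared core; the large ones exchanged the aryl on the sulfonyl sulfur, and the step from compound 1 to compound 3, which swapped a methoxy for a fluoro there, stayed within the scatter. Nothing therefore argues for a move beyond the scatter in this assay. Compound 4 is expected to give 86%, between 62% and 97%. That estimate means a number 7 percentage points lower from compound 1 to compound 4 (within the scatter).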

Compound 4, a percentage reported as inhibition, at one concentration (the size of the read-out at that concentration, not a potency): 21%
Compound 4: the middle estimate sits 65 percentage points above what was measured; the measured number lies below the stated range.
By their numbers in this assay, from the lowest: compound 4; then compound 2; then compounds 1 and 3 (each within the scatter of the next).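

Until this point only the aryl on the sulfonyl sulfur had varied, and this position on the shared core now proves sensitive in this assay: methoxy in place of methyl gives a number 72 percentage points lower from compound 1 to compound 4 (beyond the scatter). The aryl on the sulfonyl sulfur is therefore not the only part of these compounds on which the read-out depends. Nothing available explains this drop.

Going by these compounds, whether it goes with the oxygen or with the longer group stays open, and an ethyl or a hydroxyl at this place would bear on that. Also open, on these data alone, is whether methoxy here costs as much alongside a different aryl on the sulfonyl sulfur.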